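A few compounds are considered here, and "the series" means these few. Any claim that something is new, unique, unknown or untested is made for them only; others in the source may bear on it.

Working notes on the series. Inhibition is read in an ADME assay on cells for inhibition of cytochrome P450 11B1, mitochondrial (Homo sapiens), read by HTRF, with stated times of 1 h and 3 h; a higher number here means a weaker inhibitor, a lower number a stronger inhibitor. Compound 1 `CC(O)(c1cncc(-n2ncc3cc(F)ccc32)c1)C(F)(F)F` gives 47 nM. Within the data shown here, compound 2 `Cc1nn(-c2cncc(C(C)(C)O)c2)c2ccccc12` gives 779 nM, the highest of the two numbers in hand; its gap to compound 1 lies beyond the scatter, and no single-point step between the two is counted, as they differ in more than one place. Compound 3 `CC(C)(O)c1cncc(-n2nc(C3CC3)c3ccccc32)c1` has not yet been measured in this assay. It differs from compound 2 by cyclopropyl in place of methyl on an aromatic carbon. Among the measured compounds shown here, no measured pair carries this change, so the data give no direction for it; a step no larger than the scatter, in either direction, is expected. The expected step is a 1.2-fold lower number from compound 2 to compound 3 (0.08 log units; within the scatter). Compound 3 is estimated at 650 nM, with a range from 200 nM to 2000 nM.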

Compound 3, half-maximal inhibitory concentration: > 8300 nM
Compound 3 was reported as a limit; the forecaster's own chance of this, stated with the estimate: 3%; middle value at least 12-fold (1.10 log units) away from the limit.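

Cyclopropyl in place of methyl on an aromatic carbon is not a neutral change at this position: it brings an at least 10-fold higher number from compound 2 to compound 3 (1.02 log units; beyond the scatter), the first direction the series gives for any change here. With methyl, compound 2 still reads as a number, so within this pair inhibition is lost with the group of three heavy atoms. Compound 3 stands at a limit of the assay and not at a number, so the step gives only a minimum size: the limit of > 8300 nM in this assay, at which 1 of the 3 values shown sits.

The compounds shown leave open whether the loss goes with the three-membered ring itself or with the added carbons alone, since an ethyl or isopropyl group at this place appears in none of them. They also give no reading here for an amine or a methoxy group.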